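The compounds below may be only part of what the source reports. "The series", "measured", "known", "first", "only" and "open" are said of these compounds alone.

In an ADME assay on a cell-free system (plasma, Homo sapiens) for metabolic stability, read by LC-MS (on this read-out higher numbers stand for a longer-lived compound and lower numbers for a shorter-lived compound), compound 2 `CC(C)[C@H](NC(=S)[C@H](C)NC(=O)[C@@H](NC(=O)[C@H](CCC(=O)O)NCCC1CCCCC1)[C@@H](C)O)C(=O)O` gives > 116 h, which is a limit of the assay and not a number. Its place among the results is the limit of > 116 h in this assay, at which 1 of the 3 values shown sits. Compound 3 `CC(C)[C@H](NC(=O)[C@H](C)NC(=O)[C@@H](NC(=O)[C@H](CCC(=O)O)NCCC1CCCCC1)[C@@H](C)O)C(=O)O` gives 0.483 h, and compound 1 `CN[C@@H](CCC(=O)O)C(=O)N[C@H](C(=S)N[C@@H](C)C(=O)N[C@H](C(=O)O)C(C)C)[C@@H](C)O` gives 9 h.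

Compound 4 `CN[C@@H](CCC(=O)O)C(=O)N[C@H](C(=O)N[C@@H](C)C(=S)N[C@H](C(=O)O)C(C)C)[C@@H](C)O` has not yet been measured. It differs from compound 2 by hydrogen in place of cyclohexylmethyl on a saturated chain carbon bound to an amine nitrogen, which means hydrogen in place of cyclohexylmethyl on a saturated chain carbon bound to an amine nitrogen. The same difference can be read as 2-cyclohexylethyl to methyl.

For the measured compounds named here, the only measured step, an at least 240-fold lower number from compound 2 to compound 3 (2.38 log units; beyond the scatter), is large, but it lies at another place in the structure. It shows how far this assay can move in this series and does not test the present change. The firmest guide is compound 1, which carries no cyclohexylmethyl and gives 9 h. A lower number beyond the scatter is therefore expected, with an estimated step of an at least 3.8-fold lower number from compound 2 to compound 4 (0.58 log units; beyond the scatter). For compound 4, the expected half-life is 30 h, with an estimated range of 6 h to 120 h.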

Compound 4, half-life: > 91.6 h
Compound 4 gave a limit, no number; the forecaster's own chance of this, stated with the estimate: 15%; middle value at least 3.0-fold (0.48 log units) from the limit.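

For the compounds shown here, compound 2 and compound 4 each give a limit of the assay and not a number, and no step between them can be read. The compounds shown leave open how long either compound truly lasts, and whether hydrogen in place of cyclohexylmethyl changes the half-life at all.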